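Amine-linked cyclohexanol in place of oxanyl ether on the aryl

The source may report more compounds than this note shows. Statements on the series, on what has been measured and on what is new or still open speak of the compounds shown alone.

Compound 3 `FC(F)(F)c1c(-c2ccc(OC3CCOCC3)c(Cl)c2)ccn2c(CC3CC3)nnc12` holds the lowest number of the three measured in an assay on cells for displacement of a labelled ligand from metabotropic glutamate receptor 2 (Homo sapiens), read by scintillation counting, with a stated time of 60 min; a higher number here means a weaker inhibitor, a lower number a stronger inhibitor: compound 3 gives 5.25 nM. Compound 1 `CC(C)Nc1ccc(-c2ccn3c(CC4CC4)nnc3c2C(F)(F)F)cc1F` gives 8.91 nM, within the scatter of compound 3. Among the compounds with values here, compound 2 `Clc1cc(-c2ccn3c(CC4CC4)nnc3c2Cl)ccc1OC1CCOCC1` gives 22.9 nM, and the one single-point step, a 4.4-fold lower number from compound 2 to compound 3 (0.64 log units; beyond the scatter), is the only step measured so far.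

Compound 4 `O[C@]1(C2CC2)CC[C@H](Nc2ccc(-c3ccn4c(CC5CC5)nnc4c3C(F)(F)F)cc2Cl)CC1` differs from compound 3 by (4-cyclopropyl-4-hydroxycyclohexyl)amino in place of (oxan-4-yl)oxy on an aromatic carbon. Within the data shown here, no measured step concerns this change: the step from compound 2 to compound 3 alters the trifluoromethyl on the shared core, not the group on the aryl. Compounds 1 and 3 differ in two places, so their values only show that an amino-linked substituent and an oxy-linked substituent on this aryl ring both give numbers within scatter of each other.

The change from compound 3 to compound 4 is therefore expected to give no step beyond the scatter, a 1.1-fold lower number from compound 3 to compound 4 (0.02 log units; within the scatter), with wide uncertainty. Compound 4 is estimated at 5 nM, in the range 1.5 nM to 16 nM.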

Compound 4, inhibition constant: 0.891 nM
For compound 4 the middle estimate is 5.6-fold (0.75 log units) above the measured one; measured number below the stated range.
By their numbers in this assay, from the lowest: compound 4; then compounds 3 and 1 (each within the scatter of the next); then compound 2.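

In this assay, within the data shown here, the change at this position, ortho to a chloro group and on the otherwise shared core, gives a 5.9-fold lower number from compound 3 to compound 4 (0.77 log units; beyond the scatter) and is the first step measured at this place. The position therefore accepts the larger (4-cyclopropyl-4-hydroxycyclohexyl)amino in place of (oxan-4-yl)oxy with a lower number, although the link atom, the ring and the ring substituents all change in this one step. No evidence at hand bears on the cause of this step.

Which part of the entering group carries the step remains open: the amino link, the cyclohexyl ring, the hydroxy or the cyclopropyl. Also open, going by these compounds, is how a plain cyclohexylamino group, or the same 4-cyclopropyl-4-hydroxycyclohexyl group joined through oxygen, would read at this position.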